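Chloro Substitution on Two Related Cores in MCF7 Growth Inhibition

A few compounds are considered here, and "the series" means these few. Any claim that something is new, unique, unknown or untested is made for them only; others in the source may bear on it.

Compound 1, `CCN(CC)CN1C(=O)/C(=N\c2nc3ccc(C)cc3s2)c2ccccc21`: 74800 nM
Compound 2, `CCN(CC)CN1C(=O)/C(=N\c2nc3ccc(C)cc3s2)c2c(Cl)cccc21`: 19200 nM
Compound 3, `CN(C)CN1C(=O)C(=O)c2ccccc21`: 40500 nM

Three compounds were measured in a functional assay on MCF7 cells (Homo sapiens) for cytotoxicity, read by sulforhodamine B assay, with a stated time of 48 h; a lower number here means a stronger inhibitor of growth, a higher number a weaker inhibitor of growth. Compound 1 has the structure `CCN(CC)CN1C(=O)/C(=N\c2nc3ccc(C)cc3s2)c2ccccc21` and gives 74800 nM in this assay. Compound 2, `CCN(CC)CN1C(=O)/C(=N\c2nc3ccc(C)cc3s2)c2c(Cl)cccc21`, differs from it by chloro in place of hydrogen on an aromatic carbon, and in this assay compound 2 gives 19200 nM. That single change produced a 3.9-fold lower number from compound 1 to compound 2 (0.59 log units; beyond the scatter).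

Compound 3, `CN(C)CN1C(=O)C(=O)c2ccccc21`, is built on a different core. The difference between the core of compound 1 and the core of compound 3 is not broken down here. In this assay, for the measured compounds named here, compound 3 gives 40500 nM, a number within the usual scatter of the one for compound 1, so no order between those two can be stated; the number for compound 2 is lower than that for compound 3.

Compound 4, `CN(C)CN1C(=O)C(=O)c2c(Cl)cccc21`, has not yet been measured. Going by the values given here, it differs from compound 3 by chloro in place of hydrogen on an aromatic carbon, which is the same change as the one from compound 1 to compound 2, placed in the same way on the ring. The expectation rests on that single precedent alone, and on a smaller core where nothing shows how the chloro will behave. Compound 4 is therefore estimated to show a 3.1-fold lower number from compound 3 to compound 4 (0.49 log units; beyond the scatter), a step expected to fall near the earlier one while leaving room for it to be smaller. The estimated number for compound 4 in this assay is 13000 nM, with an expected range from 5000 nM to 35000 nM.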

Compound 4, concentration for 50% growth inhibition: 87800 nM
Estimate against measurement, compound 4: 6.8-fold (0.83 log units) below; measured number above the stated range.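

In this assay, chloro in place of hydrogen on an aromatic carbon gave a 2.2-fold higher number from compound 3 to compound 4 (0.34 log units; beyond the scatter), whereas the same change on the core of compound 1 gave a 3.9-fold lower number from compound 1 to compound 2 (0.59 log units; beyond the scatter), so the two steps point in opposite directions. Set side by side, the steps differ by more than repeated measurements would explain, and the gain seen with chloro on the first core did not carry over to the second: the same change on two cores in this assay, a 3.9-fold lower number (0.59 log units; beyond the scatter) from compound 1 to compound 2 and a 2.2-fold higher number (0.34 log units; beyond the scatter) from compound 3 to compound 4, 8.4-fold (0.93 log units) apart, beyond the scatter of two such steps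

This shows that, in this series, the direction of the chloro step cannot be assumed to hold from one core to the other, but it rests on a single pair on each core and does not show which part of the structure separates the two outcomes, since the two cores differ in more than one place.

The compounds shown leave open whether fluoro, bromo or methoxy on that same aromatic carbon would follow the step seen on the core of compound 1 or the one seen on the core of compound 3. They also leave open whether the diethylamino group in place of the dimethylamino group on the core of compound 3 would alter the direction of the chloro step.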